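Working notes on the shared core: estimating compound 4

The source may report more compounds than this note shows. Statements on the series, on what has been measured and on what is new or still open speak of the compounds shown alone.

Measured so far:
- compound 1, `CCCCCCOc1ccc(-n2cnnc2)cc1`; in a functional assay on the whole organism (strain C57B/6) with Mus musculus as the target, in the maximal electroshock model (on this read-out higher numbers stand for an effect only at larger amounts of compound and lower numbers for an effect already at smaller amounts), compound 1 gives 9.8 mg/kg
- compound 2, `CCCCCCOc1ccc(-n2cnnc2CCCCCC)cc1`; in this assay compound 2 reaches only the assay limit, > 40 mg/kg
- compound 3, `CCCCCCOc1ccc(-n2cnnc2-c2ccccc2F)cc1`; in this assay compound 3 gives 20.2 mg/kg

Compound 3 holds the highest of the two numbers in hand; the nearest is compound 1, and the step of a 2.1-fold higher number from compound 1 to compound 3 (0.31 log units; beyond the scatter) lies beyond the scatter. Compound 2 sits at the limit of > 40 mg/kg in this assay, at which 1 of the 3 values shown sits, and gives no number.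

Compound 4, `CCCCCCOc1ccc(-n2cnnc2CCc2ccccc2)cc1`, is not yet measured. It differs from compound 3 in one place: phenethyl in place of 2-fluorophenyl on an aromatic carbon.

Going by the values given here, three measured steps bear on this. Putting a hexyl chain on the unsubstituted carbon of compound 1 gave an at least 4.0-fold higher number from compound 1 to compound 2 (0.61 log units; beyond the scatter), and putting a 2-fluorophenyl there gave a 2.1-fold higher number from compound 1 to compound 3 (0.31 log units; beyond the scatter); both raise the number. The direct exchange an at least 1.9-fold lower number from compound 2 to compound 3 (0.29 log units; that floor lies within the scatter) has a floor that lies within the scatter, so the two large groups cannot be separated on these data. Phenethyl carries both a short chain and an aromatic ring, so a number around that of compound 3, or somewhat higher, is expected in this assay, with the step of a 1.2-fold higher number from compound 3 to compound 4 (0.09 log units; within the scatter) as the working guess. For compound 4 the estimate is 25 mg/kg, within 12 mg/kg to 60 mg/kg; a limit-only result is plausible.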

Compound 4, dose for half-maximal effect: 27.4 mg/kg
Beside the measured number, compound 4's estimate is 1.1-fold (0.04 log units) below it; measured number inside the range.
By their numbers in this assay, from the lowest: compound 1; then compounds 3 and 4 (each within the scatter of the next). At a limit, above all of these: compound 2.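

In this assay, phenethyl and 2-fluorophenyl on this aromatic carbon, between two ring nitrogen atoms, cannot be told apart: the exchange gives a 1.4-fold higher number from compound 3 to compound 4 (0.13 log units; within the scatter), so a saturated link in front of the aromatic ring makes no readable difference here. Phenethyl also joins the other two large groups in separating from the hydrogen of compound 1, with a 2.8-fold higher number from compound 1 to compound 4 (0.45 log units; beyond the scatter); across the four compounds, hydrogen at this position gives the lowest number, and no compound shown goes against this. Compound 2 gives only a limit, so phenyl in place of butyl at the chain end gives an at least 1.4-fold lower number from compound 2 to compound 4 (0.16 log units; that floor lies within the scatter), and this does not show whether the aromatic ring at the end of the chain does better than the all-carbon hexyl chain.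

What remains open is how small a group at this carbon must be to stay level with hydrogen, since a methyl or an ethyl group would fall between the cases shown. As far as these compounds go, it is also open whether a group of another kind, such as an amine or a carboxylic acid, would follow the same trend at this position.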